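A Charged Nitrogen Group Replaces the Hexylamino Chain

A few compounds are considered here, and "the series" means these few. Any claim that something is new, unique, unknown or untested is made for them only; others in the source may bear on it.

Three compounds of one shared core were measured in an assay on cells for inhibition of ileal sodium/bile acid cotransporter (Homo sapiens); on this read-out lower numbers stand for stronger inhibition and higher numbers for weaker inhibition. Compound 2 `CCCC[C@]1(CC)CS(=O)(=O)c2ccc(N)cc2[C@@H](c2ccccc2)[C@H]1O` gives 68 nM, compound 3 `CCCCCCNc1ccc2c(c1)[C@@H](c1ccccc1)[C@@H](O)[C@](CC)(CCCC)CS2(=O)=O` gives 1670 nM, and compound 1 `C=CCCCCCCCCOc1ccc2c(c1)S(=O)(=O)C[C@@](CC)(CCCC)[C@H](O)[C@@H]2c1ccccc1` gives 16000 nM. Compound 3 thus stands between the other two: its number is below that of compound 1 and well above that of compound 2, and the step of a 25-fold higher number from compound 2 to compound 3 (1.39 log units; beyond the scatter) shows how much the hexyl on the ring nitrogen raised the number. Compound 4 `CCCC[C@]1(CC)CS(=O)(=O)c2ccc([N+](C)(C)C)cc2[C@@H](c2ccccc2)[C@H]1O` differs from compound 3 by a group of 4 heavy atoms (3 carbon, 1 nitrogen; no ring) in place of a group of 7 heavy atoms (6 carbon, 1 nitrogen; no ring), on an aromatic carbon. Going by the values given here, that single step is the only one bearing here: it removes the hexyl whose addition was large, yet brings in three carbons and a positive charge, for which no measured step exists. Compound 4 is therefore expected to move back toward compound 2, giving an estimated 200 nM in this assay, between 30 nM and 1500 nM, an expected step of an 8.4-fold lower number from compound 3 to compound 4 (0.92 log units; beyond the scatter).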

Compound 4, half-maximal inhibitory concentration: 83 nM
Estimate against measurement, compound 4: 2.4-fold (0.38 log units) above; low and high end bracket the measured number.
By their numbers in this assay, from the lowest: compounds 2 and 4 (each within the scatter of the next); then compound 3; then compound 1.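

In this assay, a net charge of +1 on this aromatic carbon is accepted: exchanging the hexylamino chain for the charged nitrogen group gives a 20-fold lower number from compound 3 to compound 4 (1.30 log units; beyond the scatter). The same group in place of the plain ring nitrogen gives a 1.2-fold higher number from compound 2 to compound 4 (0.09 log units; within the scatter), so the two stand level within the scatter, and the three added carbons and the charge bring no measurable loss here. Nothing among the data explains these steps. Still open, from the compounds shown here alone, is whether an uncharged dimethylamino group would sit at the same level, and whether a hexyl chain ending in a trimethylammonium group would keep it.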